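The compounds below may be only part of what the source reports. "The series", "measured", "known", "first", "only" and "open" are said of these compounds alone.

Measured in a functional assay on the whole organism for inhibition, with Mus musculus as the target; on this read-out higher numbers stand for an effect only at larger amounts of compound and lower numbers for an effect already at smaller amounts:

- compound 1 `CCCNC(=O)Nc1cccc2c1CN(C)CC2c1ccccc1`: > 80 mg/kg
- compound 2 `CCCCNC(=O)Nc1cccc2c1CN(C)CC2c1ccc(Cl)cc1`: 44 mg/kg
- compound 3 `CCOC(=O)Nc1cccc2c1CN(C)CC2c1ccc(F)cc1`: 3.5 mg/kg

Compound 1 has no exact number, only a limit: it stands at the limit of > 80 mg/kg in this assay, at which 1 of the 3 values shown sits. Any step away from it is therefore only approximate.

Compound 4 `CCCCOC(=O)Nc1cccc2c1CN(C)CC2c1ccccc1` keeps the core of compound 1 and changes one group: butoxy in place of propylamino on a carbonyl carbon. Within the data shown here, no measured pair isolates this swap, so the expectation rests on indirect evidence. Compound 3 also has an alkoxy group on the carbonyl carbon and gives 3.5 mg/kg. Compound 2 has an alkylamino group there and gives 44 mg/kg. Those two compounds also differ in other places, which keeps the comparison loose. The direction expected in this assay is still towards smaller doses, by a margin beyond the usual scatter, and the estimated change is an at least 8.0-fold lower number from compound 1 to compound 4 (0.90 log units; beyond the scatter). For compound 4 the estimated value is 10 mg/kg. The expected range for compound 4 runs from 3 mg/kg to 40 mg/kg.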

Compound 4, dose for half-maximal effect: 4 mg/kg
For compound 4 the middle estimate is 2.5-fold (0.40 log units) above the measured one; measured number inside the range.
By their numbers in this assay, from the lowest: compounds 3 and 4 (each within the scatter of the next); then compound 2. At a limit, above all of these: compound 1.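

In this assay, with the core of compound 1 kept unchanged, butoxy in place of propylamino on a carbonyl carbon gives an at least 20-fold lower number from compound 1 to compound 4 (1.30 log units; beyond the scatter). This is the first comparison shown that changes this position alone, so the link between the group on the carbonyl carbon and the dose needed no longer rests on compounds that also differ elsewhere. The step can only be read as a minimum, as compound 1 stands at a limit and not at an exact number: the limit of > 80 mg/kg in this assay, at which 1 of the 4 values shown sits.

The swap changes both the atom attached to the carbonyl carbon and the chain length, and a propoxy group on the same carbonyl carbon would help to separate these two changes. Going by these compounds, whether a longer chain, such as hexyloxy, would keep the effect at similarly small doses also remains open.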